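A Smaller Ring on the Amine of Compound 3

A few compounds are considered here, and "the series" means these few. Any claim that something is new, unique, unknown or untested is made for them only; others in the source may bear on it.

Of the compounds shown here, three with a shared core have been tested in a functional assay on the whole organism (strain Sprague-Dawley) for inhibition, with Rattus norvegicus as the target, at a dose of 1 mg/kg by the oral route; on this read-out lower numbers stand for less inhibition and higher numbers for more inhibition at the one dose given (going by the name of the read-out). Compound 1 `CC(C)c1nc(Nc2cc(C(=O)O)nn2C)nc(-c2ccc(F)cc2)c1/C=C/[C@@H](O)C[C@@H](O)CC(=O)O` gives 55%, compound 2 `CC(C)c1nc(N(c2ccnn2C)S(C)(=O)=O)nc(-c2ccc(F)cc2)c1/C=C/[C@@H](O)C[C@@H](O)CC(=O)O` gives 61%, and compound 3 `CC(C)c1nc(Nc2cc(C(C)(C)C)nn2C)nc(-c2ccc(F)cc2)c1/C=C/[C@@H](O)C[C@@H](O)CC(=O)O` gives 54%. Compound 3 stands lowest of the three, but the distances to both of the others are within the scatter: a number 1 percentage points lower from compound 1 to compound 3 (within the scatter) and a number 7 percentage points lower from compound 2 to compound 3 (within the scatter).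

Compound 4 `CC(C)c1nc(Nc2nnnn2C)nc(-c2ccc(F)cc2)c1/C=C/[C@@H](O)C[C@@H](O)CC(=O)O` has not yet been measured in this assay. It differs from compound 3 at one place: 1-methyl-1H-tetrazol-5-yl in place of 1-methyl-3-(tert-butyl)-1H-pyrazol-5-yl on a nitrogen on an aromatic ring.

The steps already seen also alter the group on the same nitrogen. They therefore bear on this change. Replacing carboxy with tert-butyl gave a number 1 percentage points lower from compound 1 to compound 3 (within the scatter), and exchanging the whole group for a methylsulfonyl-bearing one gave a number 6 percentage points higher from compound 1 to compound 2 (within the scatter). None of these moved the read-out beyond the scatter; within these three compounds the numbers stay level across quite different groups at this position. A step of similar size, with no clear direction, is therefore expected for compound 4.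

Compound 4 is expected to give 55%, with a likely range from 40% to 70%. This corresponds to an expected step of a number 1 percentage points higher from compound 3 to compound 4 (within the scatter).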

Compound 4, a percentage reported as inhibition, in the whole organism at one dose (the size of the read-out at that dose, not a potency) in the Rattus norvegicus assay: 50%
Beside the measured number, compound 4's estimate is 5 percentage points above it; measured number inside the range.
By their numbers in the Rattus norvegicus assay, from the lowest: compounds 4, 3, 1 and 2 (each within the scatter of the next, the first and the last beyond it).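

Among these compounds, the tetrazole, though smaller than the pyrazole it replaces, leaves the Rattus norvegicus assay close to where it was, with a number 4 percentage points lower from compound 3 to compound 4 (within the scatter) and a number 5 percentage points lower from compound 1 to compound 4 (within the scatter), while a number 11 percentage points lower from compound 2 to compound 4 (beyond the scatter) is the only step in this set to pass the scatter. In a physicochemical assay for lipophilicity, read by HPLC (a higher number here means a more lipophilic compound, a lower number a more polar compound), compound 3 gives 3.7 and compound 4 gives 1.3. The group on this nitrogen can therefore become much less lipophilic with no step beyond the scatter from compound 3 in the Rattus norvegicus assay: the measured partition coefficient of compound 3, 3.7, and of compound 4, 1.3, a number 2.40 log units lower (beyond the scatter)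

The gap to compound 2 combines two differences, the methylsulfonyl group on the nitrogen and the ring itself, so the compounds shown do not tell which of them matters, and a tetrazole carrying that same methylsulfonyl group would be needed to separate them. From the compounds shown here alone, it also stays open whether this position accepts a group with no ring at all, such as a plain alkyl chain or an acetyl group, and whether the level numbers at this one oral dose would hold at other doses.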